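Lengthening the Chain of an Epoxide Ester

The source may hold more compounds than are shown below. What is called first, only, known or untested is meant among the compounds shown, and "the series" means these compounds.

Of the compounds shown here, three have been measured in a functional assay for inhibition, with Rattus norvegicus as the target; on this read-out lower numbers stand for an effect already at smaller amounts and higher numbers for an effect only at larger amounts of compound. Compound 1 `CCCCCCCCCCCCCCC1(C(=O)OCC(O)CO)CO1` gives 10 uM, compound 2 `CCCCCCCCCCCCCCC1(C(=O)OCCCC)CO1` gives 10 uM, and compound 3 `CCCCCCC1(C(=O)OC)CO1` gives 20 uM. Compound 3 thus sits at the higher end of the three numbers, yet its gap to compound 1 and to compound 2 lies within the usual scatter, so the three cannot be ranked. Among the compounds with values here, the one step between measured compounds, no change at the digits printed from compound 1 to compound 2 (within the scatter), alters the alcohol part of the ester and says nothing about the long carbon chain.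

Compound 4 `CCCCCCCCCCCCC1(C(=O)OC)CO1` differs from compound 3 by hexyl in place of hydrogen on a saturated chain carbon, six bonds along the chain from a saturated ring carbon. Within the data shown here, no measured step bears on this change directly; compounds 1 and 2 carry longer chains than compound 3 and show values a little lower, but they differ from compound 3 in more than one place. Compound 4 is therefore expected to sit close to compound 3, with a step of a 1.7-fold lower number from compound 3 to compound 4 (0.22 log units; within the scatter) at most. The estimate for compound 4 in this assay is 12 uM, in a range from 4 uM to 30 uM.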

Compound 4, minimum effective concentration: 1 uM
Compound 4: middle estimate off by 12-fold (1.08 log units), on the high side; measured number below the stated range.
By their numbers in this assay, from the lowest: compound 4; then compounds 1, 2 and 3 (each within the scatter of the next).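

In this assay, hexyl in place of hydrogen on a saturated chain carbon, six bonds along the chain from a saturated ring carbon, gives a 20-fold lower number from compound 3 to compound 4 (1.30 log units; beyond the scatter), so this position responds strongly to lengthening the carbon chain. Within the data shown here, the one earlier step changed only the alcohol part of the ester, whereas this change to the chain alone moves the number well beyond the scatter. Nothing available explains why this change has so large an effect.

On these data alone, it remains open whether the number keeps falling, levels off or rises again with a shorter or longer chain on the same methyl ester. As far as these compounds go, it is also open whether a carboxylic acid in place of the methyl ester would keep this effect at the chain length of compound 4.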